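This account rests on a few compounds, and the source may have more. Where it says the series, first, only, none or still open, it means among the compounds named here.

Working notes on the series. Of the compounds shown here, two have numbers so far in a functional assay on Bel-7402 cells (Homo sapiens) for inhibition, read by sulforhodamine B assay, with a stated time of 72 h (a lower number here means a stronger inhibitor, a higher number a weaker inhibitor), with compound 1 `C[C@H](Nc1nc(N)nc(N)c1C#N)c1nn(-c2cccc(S(C)(=O)=O)c2)c2cc(F)ccc12` at 22100 nM and compound 2 `C[C@H](Nc1ncnc2[nH]cnc12)c1nn(-c2cccnc2)c2ccc(F)cc12` at 31900 nM. These two values lie within the scatter of each other, so compound 2 cannot be separated from compound 1 on the present numbers. Compound 3 `Cc1ccc2c(c1)c([C@H](C)Nc1ncnc3[nH]cnc13)nn2-c1cccnc1` keeps the rest of compound 2 and carries methyl in place of fluoro on an aromatic carbon. Within the data shown here, no measured pair shows what this exchange does, so the expectation rests on compound 2 alone. No step beyond the scatter is expected in this assay in either direction. The estimated change is a 1.1-fold lower number from compound 2 to compound 3 (0.03 log units; within the scatter) and it should be read as no real shift. In this assay compound 3 is estimated at 30000 nM with an expected range of 12000 nM to 70000 nM around that figure.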

Compound 3, half-maximal inhibitory concentration: > 40000 nM
Compound 3 gave a limit, no number (the forecaster's own chance of this, stated with the estimate: 15%); at least 1.3-fold (0.12 log units) between middle value and limit.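

In this assay compound 3 gives > 40000 nM, which is a limit of the assay and not a number. On this aromatic carbon, methyl in place of fluoro gives an at least 1.2-fold higher number from compound 2 to compound 3 (0.09 log units; that floor lies within the scatter), so this first reading of the position shows no stronger inhibitor from the exchange, while the floor of the step does not separate the two compounds. The true size of the step stays unfixed because the reading of compound 3 is capped: the limit of > 40000 nM in this assay, at which 1 of the 3 values shown sits.

The compounds shown give only this one exchange at this carbon, so no trend across substituents can be drawn from it. From the compounds shown here alone, whether a chloro, a methoxy or a trifluoromethyl group here would give a lower number than compound 2 remains open, as does the effect of plain hydrogen at this carbon.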